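From 4-methylphenyl to naphthalen-2-yl on the sulfonamide

This account rests on a few compounds, and the source may have more. Where it says the series, first, only, none or still open, it means among the compounds named here.

Compound 3 `CCCCCCCCCCCCCCNC(=O)[C@@H](NS(=O)(=O)c1ccc(C)cc1)[C@@H](C)O` gives 15200 nM in a functional assay on SW-620 cells (Homo sapiens) for cytotoxicity, read by MTT assay, with a stated time of 48 h (a higher number here means a weaker inhibitor, a lower number a stronger inhibitor), the lowest of the three numbers. Compound 1 `CCCCCCCCCCCCCCNC(=O)[C@@H](NC(=O)c1ccco1)[C@@H](C)O` gives 200000 nM and compound 2 `C/C=C/C=C/C(=O)N[C@H](C(=O)NCCCCCCCCCCCCCC)[C@@H](C)O` gives 200000 nM; a 13-fold lower number from compound 1 to compound 3 (1.12 log units; beyond the scatter) and a 13-fold lower number from compound 2 to compound 3 (1.12 log units; beyond the scatter) are both large, while no change at the digits printed from compound 1 to compound 2 (within the scatter) shows none. Compound 4 `CCCCCCCCCCCCCCNC(=O)[C@@H](NS(=O)(=O)c1ccc2ccccc2c1)[C@@H](C)O` carries naphthalen-2-yl in place of 4-methylphenyl on a sulfonyl sulfur. Going by the values given here, none of the three measured steps alters the group on the sulfonyl sulfur, so they bear on this change only indirectly, and no direct precedent exists for it. Compound 4 is therefore expected to land near compound 3, the expected step being a 1.7-fold lower number from compound 3 to compound 4 (0.23 log units; within the scatter), a shift that may not exceed the scatter. The estimate for compound 4 is 9000 nM, within 3000 nM to 30000 nM.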

Compound 4, half-maximal inhibitory concentration: 9360 nM
For compound 4 the middle estimate is 1.0-fold (0.02 log units) below the measured one; the range from low to high includes it.
By their numbers in this assay, from the lowest: compounds 4 and 3 (each within the scatter of the next); then compounds 1 and 2 (each within the scatter of the next).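

In this assay, the change on the sulfonyl sulfur gives a 1.6-fold lower number from compound 3 to compound 4 (0.21 log units; within the scatter), so adding a second six-membered aromatic ring does not separate the two sulfonamides. The earlier steps shown here exchanged the carbonyl-linked groups for a sulfonyl-linked one, whereas this step holds the sulfonamide nitrogen and sulfonyl group fixed and varies only the carbon-only aromatic group. No available measurement bears on this result. Going by these compounds, it remains open whether a methyl group directly on the sulfonyl sulfur would shift the number. The same holds for a carboxylic acid or an amine on the aromatic ring.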